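An isobutyl amide held against the assay limit

The source may hold more compounds than are shown below. What is called first, only, known or untested is meant among the compounds shown, and "the series" means these compounds.

In an ADME assay on PBMC cells (Homo sapiens) for cytotoxicity, read by MTT assay, with a stated time of 48 h (on this read-out lower numbers stand for stronger inhibition and higher numbers for weaker inhibition), compound 1 (`NC(=O)CC[C@H](NS(=O)(=O)c1ccc([N+](=O)[O-])cc1)C(=O)O`) gives > 1000000 nM as a limit of the assay and not as a number. Compound 2 (`CCNC(=O)CC[C@H](NS(=O)(=O)c1ccc([N+](=O)[O-])cc1)C(=O)O`) gives > 1000000 nM which is also a limit. Compound 3 (`CCCCNC(=O)CC[C@H](NS(=O)(=O)c1ccc([N+](=O)[O-])cc1)C(=O)O`) gives > 1000000 nM which is again a limit. Among the compounds with values here, the series so far therefore offers only the limit of > 1000000 nM in this assay, at which 3 of the 3 values shown sit, and no true number.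

Compound 4 (`CC(C)CNC(=O)CC[C@H](NS(=O)(=O)c1ccc([N+](=O)[O-])cc1)C(=O)O`) has not yet been measured. It departs from compound 1 by isobutyl in place of hydrogen on an amide-type nitrogen with isobutyl in place of hydrogen on an amide-type nitrogen.

Within the data shown here, three measured steps bear on this change: a step that the two limits leave unreadable from compound 1 to compound 2 and a step that the two limits leave unreadable from compound 1 to compound 3 and finally a step that the two limits leave unreadable from compound 2 to compound 3 with no size to be had from any of them. The butyl change on the same nitrogen, in compound 3, is the closest in kind, yet it too gives no size or direction to carry over. No step beyond the usual scatter is therefore expected in this assay and no direction can be named. The expected step is a step that the limit leaves unreadable from compound 1 to compound 4 and it rests on those unreadable steps alone. For compound 4 the estimate is 1500000 nM with an expected range of 600000 nM to 5000000 nM and a report of only a limit is the likeliest outcome.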

Compound 4, half-maximal inhibitory concentration: > 1000000 nM
Compound 4: no number, only a limit; the forecaster's own chance of this, stated with the estimate: 90%; the middle value is on the limit's open side.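

In this assay no new step can be read from compound 4 to compound 1, compound 2 or compound 3, because all four results are limits and not numbers: the limit of > 1000000 nM in this assay, at which 4 of the 4 values shown sit.

The compounds shown leave open where their true values lie, and whether hydrogen, ethyl, butyl or isobutyl on the amide-type nitrogen makes any difference to this read-out.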